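The compounds below may be only part of what the source reports. "The series", "measured", "known", "first", "only" and "open" are said of these compounds alone.

Measured so far in a functional assay on Capan-2 cells (Homo sapiens) for inhibition, read by MTT assay, with a stated time of 72 h; on this read-out lower numbers stand for stronger inhibition of growth and higher numbers for weaker inhibition of growth:
compound 1 `COc1ccc(CNCCCNS(=O)(=O)c2cc(C(F)(F)F)cc(C(F)(F)F)c2)cc1OC` gives 15000 nM;
compound 2 `COc1cccc(CNCCCNS(=O)(=O)c2cc(C(F)(F)F)cc(C(F)(F)F)c2)c1` gives 6400 nM;
compound 3 `O=S(=O)(NCCCNCc1ccc(Cl)c(C(F)(F)F)c1)c1cc(C(F)(F)F)cc(C(F)(F)F)c1` gives 9100 nM.

For the measured compounds named here, compound 2 carries the lowest of the three numbers; its gap to compound 3 is within the scatter, and only the step of a 2.3-fold lower number from compound 1 to compound 2 (0.37 log units; beyond the scatter) lies beyond it. Compound 4 `O=S(=O)(NCCCNCc1ccc(Br)cc1)c1cc(C(F)(F)F)cc(C(F)(F)F)c1` differs from compound 2 by 4-bromophenyl in place of 3-methoxyphenyl on a saturated chain carbon bound to an amine nitrogen. The measured steps that bear on an aryl exchange on a saturated chain carbon bound to an amine nitrogen are a 1.4-fold higher number from compound 2 to compound 3 (0.15 log units; within the scatter) and a 1.6-fold lower number from compound 1 to compound 3 (0.22 log units; within the scatter), both within the scatter, so such an exchange has so far moved this assay little. For compound 4 no step beyond the scatter is therefore expected, a 1.2-fold higher number from compound 2 to compound 4 (0.07 log units; within the scatter). Compound 4 is estimated at 7500 nM, range 3000 nM to 18000 nM.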

Compound 4, concentration for 50% growth inhibition: 2000 nM
Estimate against measurement, compound 4: 3.8-fold (0.57 log units) above; measured number outside the range, below it.
By their numbers in this assay, from the lowest: compound 4; then compounds 2, 3 and 1 (each within the scatter of the next, the first and the last beyond it).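

In this assay, for the compounds shown here, the aryl exchange on a saturated chain carbon bound to an amine nitrogen, which had stayed within the scatter in the earlier compounds, now goes beyond it, with a 3.2-fold lower number from compound 2 to compound 4 (0.51 log units; beyond the scatter) and a 4.6-fold lower number from compound 3 to compound 4 (0.66 log units; beyond the scatter) and a 7.5-fold lower number from compound 1 to compound 4 (0.88 log units; beyond the scatter). Compound 4, with 4-bromophenyl, therefore stands apart as the most potent of the four compounds. Nothing available explains this result.

As far as these compounds go, it remains open whether 4-chlorophenyl, 4-fluorophenyl or unsubstituted phenyl would match 4-bromophenyl at this place. Also open, from the compounds shown here alone, is whether a longer chain in the shared core would preserve the result of compound 4.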